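Swapping the aryl group on a shared oxazole ketone core

The compounds below may be only part of what the source reports. "The series", "measured", "known", "first", "only" and "open" are said of these compounds alone.

Measured compounds:
compound 1 `N#Cc1ccccc1-c1cnc(C(=O)CCCCCCc2ccccc2)o1` — 130 nM
compound 2 `O=C(CCCCCCc1ccccc1)c1ncc(-c2ccc([N+](=O)[O-])cc2)o1` — 50 nM
compound 3 `Cc1cccc(-c2cnc(C(=O)CCCCCCc3ccccc3)o2)n1` — 3.3 nM

These three compounds share the same core and differ only in the aromatic group attached to it. In an assay (Rattus norvegicus) for inhibition of Fatty-acid amide hydrolase 1 (Homo sapiens) (on this read-out higher numbers stand for weaker inhibition and lower numbers for stronger inhibition), compound 1 gives the highest number of the three, that is the weakest inhibition; the nearest is compound 2, and the furthest is compound 3. The step of a 2.6-fold lower number from compound 1 to compound 2 (0.41 log units; beyond the scatter) is modest, while the step of a 39-fold lower number from compound 1 to compound 3 (1.60 log units; beyond the scatter) is large, and a 15-fold lower number from compound 2 to compound 3 (1.18 log units; beyond the scatter) shows the same ordering from the other side.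

Compound 4 `O=C(CCCCCCc1ccccc1)c1ncc(-c2ccncn2)o1` is not yet measured. It differs from compound 1 by pyrimidin-4-yl in place of 2-cyanophenyl on an aromatic carbon. Both measured steps from compound 1 point in the same direction: replacing 2-cyanophenyl gave a lower number in each case, modestly with 4-nitrophenyl and strongly with 6-methylpyridin-2-yl. Pyrimidin-4-yl, like 6-methylpyridin-2-yl in compound 3, is a six-membered aromatic ring with hetero atoms, so a step well beyond the scatter toward a lower number is expected, though with no close precedent its size is uncertain. The expected step is an 8.7-fold lower number from compound 1 to compound 4 (0.94 log units; beyond the scatter). Compound 4 is therefore estimated at 15 nM, with a likely range from 4 nM to 60 nM.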

Compound 4, inhibition constant: 2.3 nM
The estimate for compound 4 lay 6.5-fold (0.81 log units) above the measured number; measured number below the stated range.
By their numbers in this assay, from the lowest: compounds 4 and 3 (each within the scatter of the next); then compound 2; then compound 1.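

In this assay, pyrimidin-4-yl on this aromatic carbon, next to the ring oxygen, gives a 57-fold lower number from compound 1 to compound 4 (1.75 log units; beyond the scatter) and also a 22-fold lower number from compound 2 to compound 4 (1.34 log units; beyond the scatter) so the position can yield a large gain with a smaller group that has no substituent of its own. Exchanging 6-methylpyridin-2-yl for pyrimidin-4-yl gives a 1.4-fold lower number from compound 3 to compound 4 (0.16 log units; within the scatter) so these two groups stand level, and a methyl group on the ring is not needed for a low number here; among these four compounds, the two six-membered aromatic rings with ring nitrogen sit at the low end and the two carbon-only rings at the high end, with no compound going against that split. Nothing available gives a reason for this split.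

The compounds shown leave open whether ring nitrogen alone is enough, which a plain phenyl and an unsubstituted pyridin-2-yl on the same core would help to test. They also leave open how a carboxylic acid or an amine on this ring would fare, and whether the split holds with a shorter chain on the ketone.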